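Swapping isopropyl for cyano on the shared core

A few compounds are considered here, and "the series" means these few. Any claim that something is new, unique, unknown or untested is made for them only; others in the source may bear on it.

Measured so far:
- compound 1 `N#Cc1cnc(NC(=O)CCCOc2cccc(Cl)c2)s1`: 0.25 h
- compound 2 `CC(C)c1cnc(NC(=O)CCCOc2ccccc2)s1`: 0.117 h

Both compounds were run in an ADME assay on microsomes from liver (Homo sapiens) for metabolic stability, read by LC-MS, using NADPH, tested at 1 uM; on this read-out higher numbers stand for a longer-lived compound and lower numbers for a shorter-lived compound. Compound 1 gives 0.25 h, while compound 2 gives 0.117 h, the lower of the two numbers, and the gap between them lies beyond the usual scatter. The two compounds differ in two places at once, so no single step can be read from this pair; only the two values themselves are known.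

Compound 3 `N#Cc1cnc(NC(=O)CCCOc2ccccc2)s1` is not yet measured. It differs from compound 2 in one place: cyano in place of isopropyl on an aromatic carbon. Compound 1 already carries the cyano group on its core and gives 0.25 h, a higher number than compound 2, so the step from compound 2 to compound 3 is expected to run upward, by a modest amount that may or may not clear the scatter: a 1.7-fold higher number from compound 2 to compound 3 (0.23 log units; within the scatter). Compound 3 is therefore estimated to give 0.2 h in this assay, within a range from 0.1 h to 0.4 h.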

Compound 3, half-life in the Homo sapiens assay: 0.15 h
For compound 3 the middle estimate is 1.3-fold (0.12 log units) above the measured one; the range from low to high includes it.
By their numbers in the Homo sapiens assay, from the lowest: compounds 2, 3 and 1 (each within the scatter of the next, the first and the last beyond it).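

Among these compounds, in the Homo sapiens assay, the single change at this position gives a 1.3-fold higher number from compound 2 to compound 3 (0.11 log units; within the scatter), and the single change on the other side of the molecule, hydrogen in place of chloro on an aromatic carbon, gives a 1.7-fold lower number from compound 1 to compound 3 (0.22 log units; within the scatter). Each step therefore stays within the scatter on its own, even though compound 1 and compound 2, which differ in both places at once, lie beyond it. In a physicochemical assay for solubility, read by nephelometry, at pH 2 (on this read-out higher numbers stand for higher solubility and lower numbers for lower solubility), compound 2 gives < 1200 nM, which is a limit of the assay and not a number, while in the physicochemical assay compound 3 gives 1100 nM.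

Going by these compounds, in the physicochemical assay, the effect of cyano in place of isopropyl remains open, as the step between compound 2 and compound 3 cannot be read because of this limit: the limit of < 1200 nM in the physicochemical assay, at which 1 of the 2 values shown sits. On these data alone, it is also open how the Homo sapiens assay would respond to a clearly different group on this aromatic carbon, such as an amine, a carboxylic acid or a longer chain, and whether any such group would give a step beyond the scatter.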